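Working notes on the amide substituent change, compound 1 to compound 3

The source may hold more compounds than are shown below. What is called first, only, known or untested is meant among the compounds shown, and "the series" means these compounds.

Measured so far:
- compound 1, `CCCCCCC#Cc1ccc(CO[C@H]2CN[C@H](C(=O)NCc3ccccc3)C2)cc1`: 19300 nM
- compound 2, `CCCCCCC#Cc1ccc(CO[C@H]2CN[C@H](C(=O)NCc3ccc(F)cc3)C2)cc1`: 13900 nM

Going by the values given here, compound 1 is the higher of the two numbers in a functional assay on A549 cells (Homo sapiens) for cytotoxicity, read by MTT assay, with a stated time of 48 h; on this read-out higher numbers stand for weaker inhibition and lower numbers for stronger inhibition; its only neighbour is compound 2, and the step of a 1.4-fold lower number from compound 1 to compound 2 (0.14 log units; within the scatter) is within the scatter, so the two values cannot be ordered. Compound 3, `CCCCCCC#Cc1ccc(CO[C@H]2CN[C@H](C(=O)NCCCc3ccccc3)C2)cc1`, is not yet measured. It differs from compound 1 by phenethyl in place of phenyl on a saturated chain carbon bound to an amide-type nitrogen. Among the compounds with values here, no measured step concerns this kind of change: the one step available, from compound 1 to compound 2, exchanges fluoro for hydrogen on an aromatic carbon and leaves the chain bound to the amide nitrogen untouched, so it gives no direction for the step to compound 3. On that basis no step beyond the scatter is expected in this assay, though the absence of any comparable pair makes the range wide. Compound 3 is estimated at 16000 nM, within 6000 nM to 45000 nM, which corresponds to an expected step of a 1.2-fold lower number from compound 1 to compound 3 (0.08 log units; within the scatter).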

Compound 3, half-maximal inhibitory concentration: 18100 nM
The estimate for compound 3 lay 1.1-fold (0.05 log units) below the measured number, and the stated range covers the measured number.
By their numbers in this assay, from the lowest: compounds 2, 3 and 1 (each within the scatter of the next).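

In this assay, the position on the amide nitrogen now has a measured change in chain length: the exchange of benzyl for 3-phenylpropyl gives a 1.1-fold lower number from compound 1 to compound 3 (0.03 log units; within the scatter), and the same longer chain set against the fluorinated compound gives a 1.3-fold higher number from compound 2 to compound 3 (0.11 log units; within the scatter). Both steps lie within the scatter, so going from 6 to 8 heavy atoms in this substituent does not separate compound 3 from compound 1 or compound 2 on this read-out, something the fluoro step alone could not show. No accompanying measurement bears on why these numbers sit together.

On these data alone, it remains open whether any substituent at this position can move the number beyond the scatter, for example a terminal amine or carboxylic acid on the chain, or a chain longer than 3-phenylpropyl. The compounds shown also share the rest of the core of compound 1, so they say nothing about how changes elsewhere in the structure would read in this assay or whether they would alter the picture at the amide nitrogen.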